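The source may hold more compounds than are shown below. What is called first, only, known or untested is meant among the compounds shown, and "the series" means these compounds.

Measured compounds:
compound 1 `Cc1c(F)c(N)c2c(=O)cc(-c3ccc(N)c(F)c3)oc2c1F` — in a functional assay on HeLa cells (Homo sapiens) for cytotoxicity, read by neutral red uptake, with a stated time of 3 days (on this read-out higher numbers stand for weaker inhibition and lower numbers for stronger inhibition), compound 1 gives > 100000 nM, a limit.
compound 2 `Nc1ccc(-c2cc(=O)c3c(N)c(F)c(CO)c(F)c3o2)cc1F` — in this assay compound 2 gives 24000 nM.
compound 3 `Nc1ccc(-c2cc(=O)c3c(N)c(F)c(Cl)c(F)c3o2)cc1F` — in this assay compound 3 gives > 100000 nM, a limit.

Compound 3 thus stands at the limit of > 100000 nM in this assay, at which 2 of the 3 values shown sit. Compound 2 alone returns a number. Compound 4 `CN(C)Cc1c(F)c(N)c2c(=O)cc(-c3ccc(N)c(F)c3)oc2c1F` differs from compound 3 by (dimethylamino)methyl in place of chloro on an aromatic carbon. Among the compounds with values here, two steps touch the same position: an at least 4.1-fold higher number from compound 2 to compound 3 (0.61 log units; beyond the scatter), and an at least 4.1-fold lower number from compound 1 to compound 2 (0.61 log units; beyond the scatter); a step that the two limits leave unreadable from compound 1 to compound 3. Both readable steps point the same way, the substituent carrying a hydrogen-bond acceptor giving the lower number, the chloro the limit. Since the entering (dimethylamino)methyl also carries one hydrogen-bond acceptor, a modest drop toward the number of compound 2 is expected in this assay, though a limit remains possible. The estimate for compound 4 is 50000 nM, between 15000 nM and 150000 nM, which is the expected step of an at least 2.0-fold lower number from compound 3 to compound 4 (0.30 log units; that floor lies within the scatter).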

Compound 4, half-maximal inhibitory concentration: 8900 nM
Beside the measured number, compound 4's estimate is 5.6-fold (0.75 log units) above it, and the stated range ends above it.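

In this assay, the position ortho to two fluoro groups now gives a step between two measured numbers: a 2.7-fold lower number from compound 2 to compound 4 (0.43 log units; beyond the scatter). Against the limits, (dimethylamino)methyl gives an at least 11-fold lower number from compound 3 to compound 4 (1.05 log units; beyond the scatter) and an at least 11-fold lower number from compound 1 to compound 4 (1.05 log units; beyond the scatter), and the full size of both steps remains unknown. Hydroxymethyl and (dimethylamino)methyl return numbers, whereas methyl and chloro sit at the limit: the limit of > 100000 nM in this assay, at which 2 of the 4 values shown sit.

Open, as far as these compounds go, is whether a primary aminomethyl group, a morpholinomethyl group or a longer chain ending in an amine would lower the number further. Also open, from the compounds shown here alone, is whether a carboxylic acid at this position would return a number at all.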